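The source may report more compounds than this note shows. Statements on the series, on what has been measured and on what is new or still open speak of the compounds shown alone.

Among the compounds with values here, in a functional assay on NCI-H460 cells (Homo sapiens) for inhibition, with a stated time of 72 h (on this read-out lower numbers stand for stronger inhibition and higher numbers for weaker inhibition), compound 2 (`COc1ccc(S(=O)(=O)N2CCc3cccc(-c4ccc(C#N)cc4)c32)cc1`) gives 29.5 nM and compound 1 (`COc1ccc(S(=O)(=O)N2CCc3cccc(-c4ccc(F)c(F)c4)c32)cc1`) gives 46 nM and these two values lie within the usual scatter of each other, so compound 2 stands level with its only neighbour. Compound 3 (`COc1ccc(S(=O)(=O)N2CCc3cccc(-c4cccs4)c32)cc1`) carries thiophen-2-yl in place of 4-cyanophenyl on an aromatic carbon, and the counted difference from compound 2 is thiophen-2-yl in place of 4-cyanophenyl on an aromatic carbon in full. Within the data shown here, one measured step bears on this change, namely a 1.6-fold lower number from compound 1 to compound 2 (0.19 log units; within the scatter) at the same carbon, so no step beyond the scatter is expected. The estimated step is a 1.5-fold higher number from compound 2 to compound 3 (0.18 log units; within the scatter) and a slightly higher number is expected. Compound 3 is estimated at 45 nM with an expected range from 15 nM to 130 nM on this read-out.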

Compound 3, half-maximal inhibitory concentration: 229 nM
Compound 3: the middle estimate sits 5.1-fold (0.71 log units) below what was measured, outside the stated range (above it).
By their numbers in this assay, from the lowest: compounds 2 and 1 (each within the scatter of the next); then compound 3.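

At this aromatic carbon, 4-cyanophenyl and 3,4-difluorophenyl had stayed within the scatter of each other, but thiophen-2-yl parts from both in this assay, with a 7.8-fold higher number from compound 2 to compound 3 (0.89 log units; beyond the scatter) and a 5.0-fold higher number from compound 1 to compound 3 (0.70 log units; beyond the scatter). The position therefore does respond to the group it carries, and here the five-membered ring with sulfur goes with weaker inhibition than either six-membered carbon ring. Nothing measured here accounts for this loss. The compounds shown leave open whether it follows ring size or the sulfur atom, which furan-2-yl and pyridin-3-yl at this carbon could help separate.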